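Trimming the dimethoxyphenyl group: compound 3 to compound 4

This account rests on a few compounds, and the source may have more. Where it says the series, first, only, none or still open, it means among the compounds named here.

In a functional assay on CCRF-CEM cells (Homo sapiens) for antiproliferative activity (on this read-out lower numbers stand for stronger inhibition and higher numbers for weaker inhibition), compound 1 `COc1cc(C(=O)c2sc(-c3ccc(F)cc3)cc2N)cc(OC)c1OC` gives 15 nM. Compound 2 `COc1cc(C(=O)c2sc(-c3ccc(I)cc3)cc2N)cc(OC)c1OC` gives 150 nM in this assay, and compound 3 `COc1ccc(-c2cc(N)c(C(=O)c3cc(OC)c(OC)c(OC)c3)s2)cc1OC` gives 20 nM. Compound 3 thus stands second highest of the three numbers: the step of a 1.3-fold higher number from compound 1 to compound 3 (0.12 log units; within the scatter) is within the scatter, whereas a 7.5-fold lower number from compound 2 to compound 3 (0.88 log units; beyond the scatter) lies beyond it, as does a 10-fold higher number from compound 1 to compound 2 (1.00 log units; beyond the scatter).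

Compound 4 `COc1cccc(-c2cc(N)c(C(=O)c3cc(OC)c(OC)c(OC)c3)s2)c1` has not yet been measured in this assay. It differs from compound 3 in one place: hydrogen in place of methoxy on an aromatic carbon. The two measured steps that end at compound 3 alter the same aryl ring and therefore bear on this change; one of them was within the scatter, the other modest. None of them removes a methoxy group from a 3,4-dimethoxyphenyl, so the direct precedent is missing. The substituents on this ring have so far moved the number at most modestly, and a step of a 1.5-fold higher number from compound 3 to compound 4 (0.18 log units; within the scatter) is expected here, in either direction or none beyond the scatter. For compound 4 the estimate in this assay is 30 nM, with a range from 8 nM to 120 nM.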

Compound 4, half-maximal inhibitory concentration: 16 nM
The estimate for compound 4 lay 1.9-fold (0.27 log units) above the measured number; the range from low to high includes it.
By their numbers in this assay, from the lowest: compounds 1, 4 and 3 (each within the scatter of the next); then compound 2.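

In this assay, the change from 3,4-dimethoxyphenyl to 3-methoxyphenyl (a 1.3-fold lower number from compound 3 to compound 4 (0.10 log units; within the scatter)) shows that the methoxy para to a large group can give way to hydrogen without a change that can be read. The single methoxy also matches the 4-fluorophenyl group (a 1.1-fold higher number from compound 1 to compound 4 (0.03 log units; within the scatter)), while the 4-iodophenyl group remains apart (a 9.4-fold lower number from compound 2 to compound 4 (0.97 log units; beyond the scatter)). Among the four aryl groups shown, three therefore cannot be told apart, and compound 2 is the only one that goes against this.

From the compounds shown here alone, whether the remaining methoxy matters is still open, as is whether a hydroxyl, an amine or a carboxylic acid would be tolerated in its place on this ring. No measurement here accounts for the loss of this methoxy leaving the number within the scatter.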